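Replacing 4-methylthiophen-2-yl with 3-carbamoylphenyl on the shared core

The compounds below may be only part of what the source reports. "The series", "measured", "known", "first", "only" and "open" are said of these compounds alone.

In an ADME assay (liver) for metabolic stability, with Liver microsome (Homo sapiens) as the target, using microsomes and NADPH, with a stated time of 30 min, tested at 1 uM (a higher number here means faster removal of the compound, a lower number slower removal), compound 3 `Cc1csc(-c2cc(C(O)(C(F)(F)F)C(F)(F)F)cnc2N2CCN(S(=O)(=O)c3ccc(N)nc3)CC2)c1` gives 29 mL.min-1.g-1. Compound 1 `Nc1ccc(S(=O)(=O)N2CCN(c3ncc(C(O)(C(F)(F)F)C(F)(F)F)cc3C3CC3)CC2)cn1` gives 38 mL.min-1.g-1. The measured gap, a 1.3-fold lower number from compound 1 to compound 3 (0.12 log units; within the scatter), stays within the scatter, so these two numbers cannot be told apart. Compound 2 `CC(C)(O)C#Cc1cc(C(O)(C(F)(F)F)C(F)(F)F)cnc1N1CCN(S(=O)(=O)c2ccc(N)nc2)CC1` gives < 14 mL.min-1.g-1, which is a limit of this assay and not a number.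

Compound 4 `NC(=O)c1cccc(-c2cc(C(O)(C(F)(F)F)C(F)(F)F)cnc2N2CCN(S(=O)(=O)c3ccc(N)nc3)CC2)c1` has not yet been measured. It carries 3-carbamoylphenyl in place of 4-methylthiophen-2-yl on an aromatic carbon, meta to a 2,2,2-trifluoro-1-hydroxy-1-(trifluoromethyl)ethyl group: 3-carbamoylphenyl in place of 4-methylthiophen-2-yl on an aromatic carbon.

All three measured steps change the group at this same place, so all three bear on the new change. Going from cyclopropyl to 4-methylthiophen-2-yl made no clear difference, as a 1.3-fold lower number from compound 1 to compound 3 (0.12 log units; within the scatter) shows. The other two steps involve 3-hydroxy-3-methylbut-1-yn-1-yl and go beyond the scatter: an at least 2.7-fold lower number from compound 1 to compound 2 (0.43 log units; beyond the scatter) and an at least 2.0-fold higher number from compound 2 to compound 3 (0.31 log units; beyond the scatter). Among the compounds with values here, this place can therefore move the number, but only one of the three groups has done so, and 3-carbamoylphenyl itself is untested here.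

A small downward step is expected, no larger than the scatter, and the estimate is a 1.5-fold lower number from compound 3 to compound 4 (0.18 log units; within the scatter). The estimated value for compound 4 is 19 mL.min-1.g-1, with an expected range from 12 mL.min-1.g-1 to 32 mL.min-1.g-1.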

Compound 4, intrinsic clearance in microsomes: 17 mL.min-1.g-1
Beside the measured number, compound 4's estimate is 1.1-fold (0.05 log units) above it; the range from low to high includes it.
By their numbers in this assay, from the lowest: compounds 4, 3 and 1 (each within the scatter of the next, the first and the last beyond it). At a limit, below all of these: compound 2.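

In this assay, within the data shown here, 3-carbamoylphenyl is the first group at this position with a measured number, and not a limit, that stands clearly apart from the cyclopropyl of compound 1: a 2.2-fold lower number from compound 1 to compound 4 (0.35 log units; beyond the scatter). Measured against 4-methylthiophen-2-yl, however, the same group gives a 1.7-fold lower number from compound 3 to compound 4 (0.23 log units; within the scatter), so these two numbers cannot be told apart, even though the entering group is larger and carries 1 hydrogen-bond donor where the leaving group has 0. Compound 2 remains at a limit of the assay and not a number, so an at least 1.2-fold higher number from compound 2 to compound 4 (0.08 log units; that floor lies within the scatter) does not separate the two compounds, and the floor of this step is all that can be read from the limit: the limit of < 14 mL.min-1.g-1 in this assay, at which 1 of the 4 values shown sits.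

The compounds shown leave open whether the change in number comes from the six-membered aromatic ring or from its carbamoyl group, a question that a plain phenyl, or a phenyl carrying a nitrile or a carboxylic acid in place of the carbamoyl, could help to settle. They also leave open how a small amine or a longer chain at this position would compare with the groups shown.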